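Compound 3 to compound 4: a longer carbonate chain

A few compounds are considered here, and "the series" means these few. Any claim that something is new, unique, unknown or untested is made for them only; others in the source may bear on it.

In a functional assay on the whole organism with Rattus norvegicus as the target (on this read-out higher numbers stand for an effect only at larger amounts of compound and lower numbers for an effect already at smaller amounts), the series reads as follows:
- compound 1 `CC(=O)Oc1ccc(-c2ccccc2)cc1C(=O)O` gives 170 mg/kg
- compound 2 `O=C(O)c1cc(-c2ccccc2F)ccc1O` gives 20 mg/kg
- compound 3 `CC(=O)Oc1ccc(-c2ccc(F)cc2F)cc1C(=O)O` gives 27 mg/kg

Compound 3 (27 mg/kg) sits within the scatter of compound 2 (20 mg/kg), while compound 1 (170 mg/kg) shows a higher number, with a gap to compound 3 that lies beyond the scatter.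

The next compound is compound 4 `CCCCOC(=O)Oc1ccc(-c2ccc(F)cc2F)cc1C(=O)O` and it keeps the core of compound 3. It carries butoxy in place of methyl on a carbonyl carbon, so that acetoxy becomes (butoxycarbonyl)oxy. Within the data shown here, no pair measured so far differs in one place only, and none changes this carbonyl carbon, so the series offers no direct precedent for this step. The working expectation in this assay is therefore no step beyond the scatter, with the estimate anchored on compound 3 at 27 mg/kg and a range left wide in both directions. The estimated change is a 1.1-fold higher number from compound 3 to compound 4 (0.05 log units; within the scatter) and it is expected to stay small. Compound 4 is expected at 30 mg/kg with an estimated range of 12 mg/kg to 75 mg/kg on this read-out.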

Compound 4, dose for half-maximal effect: 12 mg/kg
Estimate against measurement, compound 4: 2.5-fold (0.40 log units) above; measured number inside the range.
By their numbers in this assay, from the lowest: compounds 4, 2 and 3 (each within the scatter of the next, the first and the last beyond it); then compound 1.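

Among these compounds, the carbonyl carbon of the acetoxy group is the first place where a single change can be read: in this assay, butoxy in place of methyl gives a 2.3-fold lower number from compound 3 to compound 4 (0.35 log units; beyond the scatter) as a modest step beyond the scatter. The position therefore accepts the change from acetoxy to (butoxycarbonyl)oxy, and on this read-out the effect appears at smaller rather than larger amounts of compound. No measurement at hand bears on the reason for this step.

A single pair cannot separate the contribution of the chain from that of the oxygen entering with butoxy, so a plain pentyl on the same carbonyl carbon, a shorter ethoxy, a longer hexyloxy or an amine in place of butoxy would each put a different part of this change to the test. Also open, on these data alone, is whether the step carries over to other cores, such as the core of compound 1, or holds only with the substitution pattern shared by compound 3 and compound 4.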